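A few compounds are considered here, and "the series" means these few. Any claim that something is new, unique, unknown or untested is made for them only; others in the source may bear on it.

Of the compounds shown here, three have been measured in an assay on isolated protein for displacement of a labelled ligand from Oxytocin receptor (Homo sapiens); a lower number here means a stronger inhibitor, a higher number a weaker inhibitor. Compound 1 `CC[C@H](C)[C@@H]1C(=O)N[C@H](C2Cc3ccccc3C2)C(=O)N1[C@@H](C(=O)N1CCOCC1)c1cnc(C)cc1C` gives 0.0501 nM in this assay. Compound 3 `CC[C@H](C)[C@@H]1C(=O)N[C@H](C2Cc3ccccc3C2)C(=O)N1[C@@H](C(=O)NC)c1cnc(C)cc1C` gives 0.0631 nM. Compound 2 `CCC(CC)[C@@H]1C(=O)N[C@H](C2Cc3ccccc3C2)C(=O)N1[C@@H](C(=O)NC)c1ccc(C)nc1C`, which rests on a different core, gives 0.0501 nM.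

The change from compound 3 to compound 1 is morpholin-4-yl in place of methylamino on a carbonyl carbon, and it gave a 1.3-fold lower number from compound 3 to compound 1 (0.10 log units; within the scatter). The difference between the core of compound 2 and the core of compound 3 is not broken down here; their values simply lie close together. Compound 2 and compound 1 stand level at the digits given, and both sit within the scatter of compound 3, so no order among the three can be read from these numbers.

Compound 4 `CCC(CC)[C@@H]1C(=O)N[C@H](C2Cc3ccccc3C2)C(=O)N1[C@@H](C(=O)N1CCOCC1)c1ccc(C)nc1C` has not yet been measured. It arises from compound 2 by morpholin-4-yl in place of methylamino on a carbonyl carbon, the same change at the same place as the one already seen. The expected step is a 1.3-fold lower number from compound 2 to compound 4 (0.10 log units; within the scatter), because the same change gave a 1.3-fold lower number from compound 3 to compound 1 (0.10 log units; within the scatter). Compound 4 is therefore expected to give 0.04 nM in this assay, most likely between 0.02 nM and 0.1 nM.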

Compound 4, inhibition constant: 0.0316 nM
Estimate against measurement, compound 4: 1.3-fold (0.10 log units) above; the range from low to high includes it.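

In this assay, morpholin-4-yl in place of methylamino on a carbonyl carbon gave a 1.6-fold lower number from compound 2 to compound 4 (0.20 log units; within the scatter), and this step can be set beside the one seen earlier on the other core: the same change on two cores in this assay, a 1.3-fold lower number (0.10 log units; within the scatter) from compound 3 to compound 1 and a 1.6-fold lower number (0.20 log units; within the scatter) from compound 2 to compound 4, 1.3-fold (0.10 log units) apart, within the scatter of two such steps. The change therefore behaved alike on the two cores shown, with the numbers staying at much the same level in both pairs. It does not show that either group is the better one, as each step on its own lies within the usual scatter, and two cores say nothing about how the change would behave on others in this series.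

The compounds shown leave open what other groups on that carbonyl carbon would do, such as piperazin-1-yl, dimethylamino or a carboxylic acid in place of the amide. They also leave open how each difference between the core of compound 2 and the core of compound 3 counts on its own, as these two differ in more than one place.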